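The source may report more compounds than this note shows. Statements on the series, on what has been measured and on what is new or still open speak of the compounds shown alone.

Compound 1 (`Nc1ccn([C@H]2O[C@@H](CO)C=C2F)c(=O)n1`) was tested in a functional assay on CCRF-CEM cells (Homo sapiens) for inhibition (a lower number here means a stronger inhibitor, a higher number a weaker inhibitor), and compound 1 gives > 100000 nM, which is a limit and not a number. Compound 2 (`Nc1ccn([C@@H]2O[C@@H](CO)C=C2F)c(=O)n1`) gives > 100000 nM, also a limit. Compound 3 (`Nc1ncnc2c1ncn2[C@@H]1O[C@@H](CO)C=C1F`) gives > 100000 nM, again a limit. Compound 1 therefore stands with the others at the limit of > 100000 nM in this assay, at which 3 of the 3 values shown sit. Among the compounds with values here, the one measured step, a step that the two limits leave unreadable from compound 1 to compound 2, reflects the fact that compounds 1 and 2 differ only in the configuration as drawn and offers no size to carry forward. Compound 4 (`Nc1nc(=O)n([C@H]2O[C@@H](CO)C=C2F)cc1F`) differs from compound 1 by fluoro in place of hydrogen on an aromatic carbon. With no readable step to draw on, no shift beyond the scatter is expected, and the estimated step is a number no higher from compound 1 to compound 4 (the limit leaves the size open). Compound 4 is expected near 100000 nM, within an estimated range of 40000 nM to 250000 nM.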

Compound 4, half-maximal inhibitory concentration: > 100000 nM
Compound 4: a limit, no number (the forecaster's own chance of this, stated with the estimate: 85%); the middle value sits exactly at the limit.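

No step can be read between compound 1 and compound 4: both values are limits, not numbers. The compounds shown leave open whether fluoro in place of hydrogen changes inhibition at all, and how strong any of these compounds really is.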